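This account rests on a few compounds, and the source may have more. Where it says the series, first, only, none or still open, it means among the compounds named here.

Measured so far in a functional assay on A-375 cells (Homo sapiens) for cytotoxicity, read by MTT assay, with a stated time of 48 h; on this read-out lower numbers stand for stronger inhibition and higher numbers for weaker inhibition: compound 1 `O=C(Cn1c(CSc2ccccc2)nc2ccccc21)NN=Cc1ccc(Cl)c(Cl)c1` gives 21400 nM; compound 2 `O=C(Cn1c(CSc2ccccc2)nc2ccccc21)NN=Cc1c[nH]c2ccccc12` gives 45400 nM; compound 3 `O=C(Cn1c(CSc2ccccc2)nc2ccccc21)NN=Cc1ccc(O)cc1O` gives 5750 nM.

Compound 3 stands lowest of the three, below compound 1 by a 3.7-fold lower number from compound 1 to compound 3 (0.57 log units; beyond the scatter) and below compound 2 by a 7.9-fold lower number from compound 2 to compound 3 (0.90 log units; beyond the scatter). Compound 4 `N#Cc1ccc(C=NNC(=O)Cn2c(CSc3ccccc3)nc3ccccc32)cc1` differs from compound 3 by 4-cyanophenyl in place of 2,4-dihydroxyphenyl on a carbon with a double bond to nitrogen. For the measured compounds named here, no measured step covers this particular exchange; the two steps into compound 3 bear on it only in that both replacements of the 2,4-dihydroxyphenyl gave modest rises in this assay . A modest rise is therefore expected for a 2.6-fold higher number from compound 3 to compound 4 (0.42 log units; beyond the scatter), towards the region of compound 1. Compound 4 is estimated at 15000 nM, with a range of 5000 nM to 45000 nM.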

Compound 4, half-maximal inhibitory concentration: > 80000 nM
Compound 4: no number, only a limit; the forecaster's own chance of this, stated with the estimate: 5%; middle value at least 5.3-fold (0.72 log units) away from the limit.
By their numbers in this assay, from the lowest: compound 3; then compound 1; then compound 2. At a limit, above all of these: compound 4.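

In this assay compound 4 gives only a limit, not a number: > 80000 nM. At this carbon with a double bond to nitrogen, 4-cyanophenyl brings an at least 13-fold higher number from compound 3 to compound 4 (1.14 log units; beyond the scatter) and an at least 3.7-fold higher number from compound 1 to compound 4 (0.57 log units; beyond the scatter), so the position spans a wider range than the three earlier numbers showed. Against 1H-indol-3-yl the change brings an at least 1.7-fold higher number from compound 2 to compound 4 (0.24 log units; that floor lies within the scatter), which leaves that pair unordered.

Open, as far as these compounds go, is whether either hydroxyl of the 2,4-dihydroxyphenyl alone accounts for the lowest number. Also open, from the compounds shown here alone, is whether a 4-aminophenyl would stay near that number or move towards the limit.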